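The source may report more compounds than this note shows. Statements on the series, on what has been measured and on what is new or still open speak of the compounds shown alone.

Among the compounds with values here, the three measured compounds share a core that carries a methyl group and a second, larger group on an aromatic nitrogen, joined to a six-membered aromatic ring of carbon only that bears an alkyl group. Compound 1 `Cc1[nH]c(=O)n(C)c1-c1ccc(C2CCCCC2)cc1` has a cyclohexyl on that ring and a methyl on the nitrogen; in a functional assay on brain (Rattus norvegicus, strain Wistar) for inhibition (a lower number here means a stronger inhibitor, a higher number a weaker inhibitor), compound 1 gives 10000 nM. Compound 2 `CCCCCCCc1ccc(-c2c(C)[nH]c(=O)n2C)cc1` differs from compound 1 by heptyl in place of cyclohexyl on an aromatic carbon; in this assay compound 2 gives 8400 nM, and the step of a 1.2-fold lower number from compound 1 to compound 2 (0.08 log units; within the scatter) stays within the scatter. Compound 3 `Cc1[nH]c(=O)n(C2CCCCC2)c1-c1ccc(C2CCCCC2)cc1` differs from compound 1 by cyclohexyl in place of methyl on an aromatic nitrogen, which is how the two cores differ; in this assay compound 3 gives 28900 nM, the step being a 2.9-fold higher number from compound 1 to compound 3 (0.46 log units; beyond the scatter).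

Compound 4 `CCCCCCCc1ccc(-c2c(C)[nH]c(=O)n2C2CCCCC2)cc1` has not been measured. It differs from compound 3 by heptyl in place of cyclohexyl on an aromatic carbon. Within the data shown here, this is the same kind of change as the one between compound 1 and compound 2, though the surroundings read slightly differently: in compound 3 the heptyl enters para to a large group, whereas in compound 1 it enters para to a group of 8 heavy atoms. Resting on the earlier step of a 1.2-fold lower number from compound 1 to compound 2 (0.08 log units; within the scatter), which lay within the scatter, the expected step is a 1.2-fold lower number from compound 3 to compound 4 (0.08 log units; within the scatter). Compound 4 is therefore estimated at 24000 nM in this assay. Among the measured compounds shown here, for compound 4 the estimated range runs from an expected lower end of 11000 nM to an expected upper end of 55000 nM, a width that allows for the usual scatter and for the fact that only one earlier example of this change exists.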

Compound 4, half-maximal inhibitory concentration: 8700 nM
The estimate for compound 4 lay 2.8-fold (0.44 log units) above the measured number, and the stated range ends above it.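

In this assay, heptyl in place of cyclohexyl on an aromatic carbon gives a 3.3-fold lower number from compound 3 to compound 4 (0.52 log units; beyond the scatter), so the small effect of this change on the core of compound 1 did not carry over to the core of compound 3: the same change on two cores in this assay, a 1.2-fold lower number (0.08 log units; within the scatter) from compound 1 to compound 2 and a 3.3-fold lower number (0.52 log units; beyond the scatter) from compound 3 to compound 4, 2.8-fold (0.45 log units) apart, beyond the scatter of two such steps. The same four compounds can be read along the other change, cyclohexyl in place of methyl on an aromatic nitrogen, which gives a 1.0-fold higher number from compound 2 to compound 4 (0.02 log units; within the scatter) when heptyl is on the carbon ring and so differs from its effect when cyclohexyl is there: the same change on two cores in this assay, a 2.9-fold higher number (0.46 log units; beyond the scatter) from compound 1 to compound 3 and a 1.0-fold higher number (0.02 log units; within the scatter) from compound 2 to compound 4, 2.8-fold (0.45 log units) apart, beyond the scatter of two such steps. The two changes therefore do not simply add up in these compounds, and a step measured on one core is a poor guide to the other, but both comparisons come from a single set of four compounds, so they count as one observation and show neither why the steps differ nor how widely this holds in the series.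

From the compounds shown here alone, it remains open whether a shorter chain such as butyl or a longer chain such as decyl on the carbon ring would behave like heptyl or like cyclohexyl. Going by these compounds, it is equally open how ethyl or benzyl on the nitrogen, or an amine or a carboxylic acid at the end of the chain, would fit this picture.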